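Shortening the hydroxycarbamoyl chain: compound 2 to compound 3

The compounds below may be only part of what the source reports. "The series", "measured", "known", "first", "only" and "open" are said of these compounds alone.

Measured so far:
- compound 1 `CC(C)c1cc(-c2n[nH]c(=O)n2-c2cccc(C(=O)NCCCC(=O)NO)c2)c(O)cc1O` at 4600 nM 
- compound 2 `CC(C)c1cc(-c2n[nH]c(=O)n2-c2cccc(C(=O)NCCCCCCC(=O)NO)c2)c(O)cc1O` at 4600 nM 

In a functional assay on HEL cells (Homo sapiens) for inhibition (a lower number here means a stronger inhibitor, a higher number a weaker inhibitor), compound 2 gives 4600 nM and stands level with compound 1. The next compound is compound 3 `CC(C)c1cc(-c2n[nH]c(=O)n2-c2cccc(C(=O)NCCCCC(=O)NO)c2)c(O)cc1O`, reached by hydroxycarbamoyl in place of 2-(hydroxycarbamoyl)ethyl on a saturated chain carbon, four bonds along the chain from an amide-type nitrogen, with hydroxycarbamoyl in place of 2-(hydroxycarbamoyl)ethyl on a saturated chain carbon. Among the measured compounds shown here, the one measured step bearing on this, no change at the digits printed from compound 1 to compound 2 (within the scatter), also alters this chain and stays within the scatter. No shift beyond the scatter is therefore expected in this assay, and neither direction is favoured. The expected no change at the digits printed from compound 2 to compound 3 (within the scatter) is accordingly small. Compound 3 is estimated at 4600 nM, within an expected range of 2000 nM to 10000 nM for further measurement.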

Compound 3, half-maximal inhibitory concentration: 4600 nM
Beside the measured number, compound 3's estimate shows no gap at the digits printed, within the range that was stated.
By their numbers in this assay, from the lowest: compounds 1, 2 and 3 (each within the scatter of the next).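

In this assay, (hydroxycarbamoyl)methyl in place of hydroxycarbamoyl gives no change at the digits printed from compound 1 to compound 3 (within the scatter), and hydroxycarbamoyl in place of 2-(hydroxycarbamoyl)ethyl gives no change at the digits printed from compound 2 to compound 3 (within the scatter). The flat reading for chain length at this position now rests on three compounds rather than one pair, and none of the three goes against it. No evidence at hand bears on this result.

Still open, on these data alone, is whether a carboxylic acid in place of hydroxycarbamoyl, or a chain longer than that of compound 2, would shift the value in this assay.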